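The source may hold more compounds than are shown below. What is called first, only, known or untested is meant among the compounds shown, and "the series" means these compounds.

Measured compounds:
compound 1 `CCCCCC(=O)OCC(COC(=O)CCCCC)O[C@@H]1O[C@H](CS(=O)(=O)O)[C@@H](O)[C@H](O)[C@H]1O`, 13%
compound 2 `CCCCCCCCCCCCCCCCCC(=O)OCC(CO)O[C@@H]1O[C@H](CS(=O)(=O)O)[C@@H](O)[C@H](O)[C@H]1O`, 86%
compound 3 `CCCCCCCCCCCC(=O)OCC(CO)O[C@@H]1O[C@H](CS(=O)(=O)O)[C@@H](O)[C@H](O)[C@H]1O`, 31%

In an assay on isolated protein for inhibition of RAC-alpha serine/threonine-protein kinase (Homo sapiens), read by ELISA, tested at 100 uM (on this read-out higher numbers stand for more inhibition at the one concentration tested (going by the name of the read-out) and lower numbers for less inhibition), compound 3 stands second highest of the three numbers; compound 1 sits lower and compound 2 higher, both beyond the scatter. Compound 4 `CCCCCC(=O)OCC(CO)O[C@@H]1O[C@H](CS(=O)(=O)O)[C@@H](O)[C@H](O)[C@H]1O` differs from compound 3 by hydrogen in place of hexyl on a saturated chain carbon, five bonds along the chain from a carbonyl carbon. Among the compounds with values here, the one step that bears on this is a number 55 percentage points lower from compound 2 to compound 3 (beyond the scatter), where removing a hexyl from the long chain cost a large amount of inhibition. Shortening the chain further in compound 4 is therefore expected to lower the number again, by a step of roughly a number 21 percentage points lower from compound 3 to compound 4 (beyond the scatter). Compound 1, which also carries only a short acyl chain, gives 13% and supports a low value. Compound 4 is estimated at 10%, within 0% to 28%.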

Compound 4, a percentage reported as inhibition, at one concentration (the size of the read-out at that concentration, not a potency): 18%
Beside the measured number, compound 4's estimate is 8 percentage points below it; measured number inside the range.
By their numbers in this assay, from the lowest: compounds 1 and 4 (each within the scatter of the next); then compound 3; then compound 2.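

In this assay, hydrogen in place of hexyl five bonds along the chain from a carbonyl carbon gives a number 13 percentage points lower from compound 3 to compound 4 (beyond the scatter) and so a modest step, against a number 55 percentage points lower from compound 2 to compound 3 (beyond the scatter) for the same change on the longer chain. The full loss of dodecyl reads a number 68 percentage points lower from compound 2 to compound 4 (beyond the scatter) across the series. Hydrogen in place of pentylcarbonyl on an oxygen on a saturated carbon gives a number 5 percentage points higher from compound 1 to compound 4 (within the scatter) and so separates nothing, and no data on hand explain these steps.

From the compounds shown here alone, whether a chain longer than that of compound 2 raises the number further stays open. So does the effect of an amine in place of the hexyl of compound 3.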